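A dimethylamino group in place of methyl

This account rests on a few compounds, and the source may have more. Where it says the series, first, only, none or still open, it means among the compounds named here.

In a functional assay on the whole organism (stomach) with Rattus norvegicus as the target (a higher number here means that more compound is needed for the effect, a lower number that less compound is needed), compound 3 `C/N=C(/NC#N)NCCCCn1nc(C)ccc1=O` gives only a limit, > 100 mg/kg. Compound 1 `C/N=C(\S)NCCCCn1nc(C)ccc1=O` likewise reaches only a limit, > 100 mg/kg. Compound 2 `CCC/N=C(/NC#N)NCCCCCn1nc(-c2ccccc2)ccc1=O` also stops at a limit, > 100 mg/kg. Going by the values given here, all three values therefore sit at the same place, (the limit of > 100 mg/kg in this assay, at which 3 of the 3 values shown sit), and the one change that links two of them, a step that the two limits leave unreadable from compound 1 to compound 3, cannot be read in size. Compound 4 `C/N=C(/NC#N)NCCCCn1nc(N(C)C)ccc1=O` differs from compound 3 as follows: dimethylamino in place of methyl on an aromatic carbon. Among the compounds with values here, no measured step touches the aromatic carbon that carries this group, and the measured compounds give no direction for the change; the only guide is that every one of them sits at the limit. Compound 4 is therefore expected to give about 100 mg/kg in this assay, within 30 mg/kg to 300 mg/kg. The change is estimated as a number no higher from compound 3 to compound 4 (the limit leaves the size open), with a strong chance that only a limit is reported again.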

Compound 4, dose for half-maximal effect: > 100 mg/kg
Compound 4 was reported as a limit; the forecaster's own chance of this, stated with the estimate: 75%; the middle value sits exactly at the limit.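

Compound 4 gives > 100 mg/kg in this assay, which is a limit, so the step from compound 3 to compound 4 cannot be read in size. The compounds shown leave open what dose any of them needs for the effect, because all stand at one place: the limit of > 100 mg/kg in this assay, at which 4 of the 4 values shown sit.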